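Swapping Fluoro for Dimethylamino on a Second Core

The compounds below may be only part of what the source reports. "The series", "measured", "known", "first", "only" and "open" are said of these compounds alone.

Compound 3 `Cc1ccc2nc(-c3ccccc3F)[nH]c(=O)c2c1` was tested in an assay on isolated protein for inhibition of DNA topoisomerase 1 (Homo sapiens), with a stated time of 30 min, tested at 20 uM (on this read-out lower numbers stand for a weaker effect and higher numbers for a stronger effect at the one concentration tested), where compound 3 gives 36.3%. Compound 1 `Cc1ccc2nc(-c3ccccc3N(C)C)[nH]c(=O)c2c1` shares the core of compound 3 and in this assay compound 1 gives 21.1%. The change between the two, (dimethylamino in place of fluoro on an aromatic carbon), made a step of a number 15.2 percentage points lower from compound 3 to compound 1 (beyond the scatter). Compound 2 `Cc1ccc2c(=O)[nH]c(-c3ccccc3F)nc2c1` has the same atoms as compound 3, joined differently; the difference between the two cores is not broken down here. In this assay compound 2 gives 0%, the lowest of the three numbers. Compound 4 `Cc1ccc2c(=O)[nH]c(-c3ccccc3N(C)C)nc2c1` has not yet been measured in this assay. It differs from compound 2 by dimethylamino in place of fluoro on an aromatic carbon, the same change, at the same place, as that from compound 3 to compound 1. That change already gave a number 15.2 percentage points lower from compound 3 to compound 1 (beyond the scatter), and compound 2 starts from 0%, a number that can hardly fall further. The expected step is therefore a number 3 percentage points higher from compound 2 to compound 4 (within the scatter). Compound 4 is estimated at 3%, with a likely range from 0% to 15%.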

Compound 4, a percentage reported as inhibition, at one concentration (the size of the read-out at that concentration, not a potency): 5.3%
Compound 4: the middle estimate sits 2.3 percentage points below what was measured, and the stated range covers the measured number.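

In this assay, dimethylamino in place of fluoro on an aromatic carbon gave a number 5.3 percentage points higher from compound 2 to compound 4 (within the scatter). Set beside the earlier step, the change did not carry over in size from one core to the other: the same change on two cores in this assay, a number 15.2 percentage points lower (beyond the scatter) from compound 3 to compound 1 and a number 5.3 percentage points higher (within the scatter) from compound 2 to compound 4, 20.5 percentage points apart, beyond the scatter of two such steps. Going by these compounds alone, compound 2 gives 0%, a number that can hardly fall further, and a drop of the earlier size could not have appeared on its core, so the gap shows only that the step did not transfer between these two pairs, not how the change would behave on a core with a higher starting number.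

Only fluoro and dimethylamino are shown at this place, and what a methoxy group, a hydroxyl group or a smaller amine such as methylamino would give there on either core stays open. The methyl group on the shared core is likewise the only group shown at its place, which leaves open what a chloro group or a longer chain would give there.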